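The source may hold more compounds than are shown below. What is called first, only, known or untested is meant among the compounds shown, and "the series" means these compounds.

Measured compounds:
Compound 1, `Cc1ccc2c(NCc3ccc(NC(=O)C4CCN(Cc5ccco5)CC4)cc3)nc(N(C)C)nc2c1`. In a functional assay on SV5A8 cells (Homo sapiens) for cytotoxicity (a higher number here means a weaker inhibitor, a lower number a stronger inhibitor), compound 1 gives > 20000 nM, which is a limit of the assay and not a number.
Compound 2, `Cc1ccc(CN2CCC(C(=O)Nc3ccc(CNc4nc(N(C)C)nc5cc(C)ccc45)cc3)CC2)cc1`. In this assay compound 2 gives > 4150 nM, again a limit and not a number.

Compound 2 therefore stands only at a limit, as does compound 1; the step that the two limits leave unreadable from compound 1 to compound 2 joins the limit of > 20000 nM in this assay, at which 1 of the 2 values shown sits, to the limit of > 4150 nM in this assay, at which 1 of the 2 values shown sits, and its size cannot be read.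

Compound 3, `Cc1ccc2c(NCc3ccc(NC(=O)C4CCN(C(=O)OC(C)(C)C)CC4)cc3)nc(N(C)C)nc2c1`, is not yet measured in this assay. The change is tert-butoxycarbonyl in place of 4-methylbenzyl on an amine nitrogen in a ring. For the measured compounds named here, the single measured step, a step that the two limits leave unreadable from compound 1 to compound 2, touches the same ring nitrogen but with a different group and carries no readable size, so it gives no direction for this exchange. With both measured compounds at limits, the step that the limit leaves unreadable from compound 2 to compound 3 is expected to stay within the scatter. Compound 3 is estimated at 15000 nM, within 4000 nM to 60000 nM, and is expected most likely to be reported as a limit only.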

Compound 3, half-maximal inhibitory concentration: > 4820 nM
Compound 3 was reported as a limit; the forecaster's own chance of this, stated with the estimate: 70%; the middle value lies beyond the limit too.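

The steps to compound 3 from compound 1 and from compound 2 cannot be read, as all three values are limits and not numbers. Still open in this assay is how the group on the ring nitrogen bears on the read-out, as no compound shown gives a number.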